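This account rests on a few compounds, and the source may have more. Where it says the series, first, only, none or still open, it means among the compounds named here.

Among the compounds with values here, the two measured members, compound 1 `O=C(Nc1cccc(-n2cc(-c3ccncc3)c(-c3cc(O)cc(Cl)c3)n2)c1)Nc1ccc(Cl)c(Cl)c1` and compound 2 `COc1cc(Cl)cc(-c2nn(-c3cccc(NC(=O)Nc4cc(C(F)(F)F)cc(C(F)(F)F)c4)c3)cc2-c2ccncc2)c1`, share one core and were tested side by side. In a functional assay on UO-31 cells (Homo sapiens) for inhibition, read by sulforhodamine B assay, with a stated time of 48 h, tested at 0.1 uM (on this read-out higher numbers stand for a weaker effect at the one concentration tested and lower numbers for a stronger effect), compound 1 gives 93%, the higher of the two numbers recorded, while compound 2 gives 75%, a gap that lies beyond the usual scatter. Compound 2 differs from compound 1 in more than one place, so its lower number cannot be assigned to any single change. Compound 3 `COc1cc(Cl)cc(-c2nn(-c3cccc(NC(=O)Nc4ccc(Cl)c(Cl)c4)c3)cc2-c2ccncc2)c1` has not yet been measured. It differs from compound 1 in one place only: methyl in place of hydrogen on an oxygen on an aromatic ring. Within the data shown here, compound 2 also carries a methoxy group and gives 75%, which hints at a downward direction, but with no single-change step available only a small downward step in this assay is expected, a number 8 percentage points lower from compound 1 to compound 3 (within the scatter), one that may well stay within the scatter. Compound 3 is therefore estimated to give 85%, within a range from 68% to 98%.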

Compound 3, a percentage reported as activity, at one concentration (the size of the read-out at that concentration, not a potency): 500%
Compound 3: middle estimate off by 415 percentage points, on the low side; the measured number lies above the stated range.
By their numbers in this assay, from the lowest: compound 2; then compound 1; then compound 3.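

In this assay, within the data shown here, the first single-change step, a number 407 percentage points higher from compound 1 to compound 3 (beyond the scatter), shows that the oxygen on the aromatic ring is not a silent place: going from hydroxy to methoxy moves the number sharply towards a weaker effect at the one concentration tested. The earlier pair could not show this, as its two members differ in more than one place. Nothing at hand accounts for the size of this step.

The compounds shown leave open whether this step is particular to methoxy or would also appear with an ethoxy group or an amine on the same aromatic ring. They also leave open whether replacing methoxy with hydroxy in compound 2 would give a step of similar size and direction.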